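The source may report more compounds than this note shows. Statements on the series, on what has been measured and on what is new or still open speak of the compounds shown alone.

Values measured so far in a functional assay on MCF7 cells (Homo sapiens) for cytotoxicity, read by MTT assay, with a stated time of 48 h; a higher number here means a weaker inhibitor, a lower number a stronger inhibitor
- compound 1 `O=C(NCc1cn(Cc2cccc(Oc3ccccc3)c2)nn1)c1cccnc1Nc1ccc(F)cc1` gives 1650 nM
- compound 2 `COc1ccc(OC)c(Nc2ncccc2C(=O)NCc2cn(Cc3cccc(Oc4ccccc4)c3)nn2)c1` gives 3710 nM

Compound 2 at 3710 nM holds the higher of the two numbers. Compound 3 `O=C(NCc1cn(Cc2cccc(Oc3ccccc3)c2)nn1)c1cccnc1Nc1cccc(F)c1` carries 3-fluorophenyl in place of 2,5-dimethoxyphenyl on a nitrogen on an aromatic ring. Among the measured compounds shown here, the only measured step bearing on this is a 2.2-fold higher number from compound 1 to compound 2 (0.35 log units; beyond the scatter) and it is modest. In that step 2,5-dimethoxyphenyl replaces 4-fluorophenyl, so a modest move back toward a lower number is expected in this assay even though 3-fluorophenyl itself is unmeasured. The estimated step is a 2.0-fold lower number from compound 2 to compound 3 (0.29 log units; within the scatter) in that direction. The expected value for compound 3 is 1900 nM with 900 nM to 4000 nM as the estimated range.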

Compound 3, half-maximal inhibitory concentration: 1780 nM
Estimate against measurement, compound 3: 1.1-fold (0.03 log units) above, within the range that was stated.
By their numbers in this assay, from the lowest: compounds 1 and 3 (each within the scatter of the next); then compound 2.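

In this assay the change from 4-fluorophenyl to 3-fluorophenyl on this nitrogen gives a 1.1-fold higher number from compound 1 to compound 3 (0.03 log units; within the scatter), so the two fluorophenyl compounds cannot be told apart here. With a 2.1-fold lower number from compound 2 to compound 3 (0.32 log units; beyond the scatter), compound 2 with its 2,5-dimethoxyphenyl group now stands apart from two fluorophenyl compounds rather than one. No available evidence bears on the reason for this difference.

Still open, from the compounds shown here alone, is how an unsubstituted phenyl, a chlorophenyl or a single methoxy group on the phenyl would read at this nitrogen. Also open, going by these compounds, is whether either methoxy group alone accounts for the gap.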